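This account rests on a few compounds, and the source may have more. Where it says the series, first, only, none or still open, it means among the compounds named here.

Measured so far:
compound 1, `NC(=S)N/N=C(/COc1ccc(Br)cc1)c1ccc(Cl)cc1`: 25100 nM
compound 2, `CNC(=S)N/N=C(/COc1ccc(Br)cc1)c1ccc(OC)cc1`: "not determined" (no result reported)
compound 3, `NC(=S)N/N=C(\COc1ccccc1)c1ccc(Br)cc1`: 54900 nM

In an ADME assay on L929 cells (Mus musculus) for cytotoxicity, read by resazurin assay, with a stated time of 96 h (on this read-out higher numbers stand for lower toxicity in this test and lower numbers for higher toxicity in this test), compound 3 gives 54900 nM, the highest of the two numbers available. Its nearest neighbour is compound 1, which gives 25100 nM; the gap between the two lies beyond the scatter. Compound 2 has no reported number.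

Compound 4, `NC(=S)N/N=C(\COc1ccc(I)cc1)c1ccc(Br)cc1`, is the next compound to be measured in this assay. It differs from compound 3 in one place: iodo in place of hydrogen on an aromatic carbon. Among the measured compounds shown here, no step between two measured compounds shows this change, so the size of its effect is open; a modest move toward a lower number is expected, possibly still within the scatter. For compound 4 the estimated value is 32000 nM, with a range from 12000 nM to 75000 nM. This corresponds to an expected 1.7-fold lower number from compound 3 to compound 4 (0.23 log units; within the scatter).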

Compound 4, half-maximal cytotoxic concentration: < 20400 nM
Compound 4 gave a limit, no number (the forecaster's own chance of this, stated with the estimate: 5%); at least 1.5-fold (0.19 log units) between middle value and limit.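

In this assay, among the compounds shown here, the step shows for the first time what a single change on this ring does: iodo in place of hydrogen on an aromatic carbon, para to a large group, gives an at least 2.6-fold lower number from compound 3 to compound 4 (0.42 log units; beyond the scatter) and so moves toward higher toxicity in this test. For the compounds shown here, this is the first step that can be read beyond the scatter. The reading of compound 4 is a limit, not a number: the limit of < 20400 nM in this assay, at which 1 of the 4 values shown sits.

Open, on these data alone, is how far the true value of compound 4 lies from that limit. Also open, as far as these compounds go, is whether fluoro, an amine or a carboxylic acid at the same place would give a step of like size.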